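This account rests on a few compounds, and the source may have more. Where it says the series, first, only, none or still open, it means among the compounds named here.

Measured so far in a functional assay on MDA-MB-231 cells (Homo sapiens) for cytotoxicity, read by MTT assay, with a stated time of 48 h; on this read-out lower numbers stand for stronger inhibition and higher numbers for weaker inhibition:
- compound 1 `O=C1CNc2nc(Nc3ccc(F)cc3)ncc2N1` gives > 100000 nM, a limit of the assay.
- compound 2 `O=C1CNc2nc(Nc3ccc(Cl)cc3)ncc2N1` gives 41700 nM.
- compound 3 `COc1ccc(Nc2ncc3c(n2)NCC(=O)N3)cc1` gives > 100000 nM, a limit of the assay.

Compound 2 stands as the only one of the three with a number in this assay. The remaining two readings are the limit of > 100000 nM in this assay, at which 2 of the 3 values shown sit. Among the measured steps, an at least 2.3-fold lower number from compound 1 to compound 2 (0.37 log units; beyond the scatter) and an at least 2.3-fold higher number from compound 2 to compound 3 (0.37 log units; beyond the scatter) both change the group on the aromatic carbon of the aniline ring, while a step that the two limits leave unreadable from compound 1 to compound 3 cannot be read between its two limits.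

Compound 4 `CN1CC(=O)Nc2cnc(Nc3ccc(Cl)cc3)nc21` differs from compound 2 by methyl in place of hydrogen on a nitrogen on an aromatic ring in a ring. Within the data shown here, none of the measured steps touches this position; all three concern the group on the aniline carbon, and the chloro group that gives compound 2 its number is kept in compound 4. Among the measured compounds shown here, no measured step therefore speaks to the size or direction of this change. Compound 4 is expected to stay close to the number already seen, the expected step being a 1.0-fold lower number from compound 2 to compound 4 (0.02 log units; within the scatter), within the scatter. The estimate for compound 4 in this assay is 40000 nM, with a range from 12000 nM to 150000 nM.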

Compound 4, half-maximal inhibitory concentration: > 100000 nM
Compound 4: a limit, no number (the forecaster's own chance of this, stated with the estimate: 30%); at least 2.5-fold (0.39 log units) between middle value and limit.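

In this assay, among these compounds, methyl in place of hydrogen on this nitrogen gives an at least 2.3-fold higher number from compound 2 to compound 4 (0.37 log units; beyond the scatter), the first reading at a position that the aniline-ring steps left untouched, and it shows that this nitrogen is not a silent site. The reading of compound 4 is a limit of the assay, so the step fixes a direction and a least size, while its full size stays unread. With the chloro group kept, the number seen for compound 2 does not carry over once the methyl is present, and compound 2 remains the only compound with a number: the limit of > 100000 nM in this assay, at which 3 of the 4 values shown sit.

Going by these compounds, whether an ethyl group, or a longer chain ending in an amine, on this nitrogen would also leave the reading at the limit stays open. Also open, on these data alone, is whether any group on the aniline ring other than chloro, such as bromo or trifluoromethyl, would give a number in the presence of this methyl, or a lower number than compound 2 without it.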